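The source may report more compounds than this note shows. Statements on the series, on what has been measured and on what is new or still open speak of the compounds shown alone.

Compound 1 `O=C(O)c1ccc2nc(CN3CCC[C@H](O[C@H](CO)c4cc(Cl)cc(Cl)c4)[C@@H]3c3ccccc3)[nH]c2c1`: 43000 nM
Compound 2 `Cc1cc(C(=O)O)ccc1CN1CCC[C@H](O[C@H](CO)c2cc(Cl)nc(Cl)c2)[C@@H]1c1ccccc1`: > 200000 nM

Within the data shown here, in an assay on isolated protein for activation of cGMP-dependent protein kinase 1 (Homo sapiens), read by ADP-Glo, with stated times of 30 min and 2 h (on this read-out lower numbers stand for an effect already at smaller amounts and higher numbers for an effect only at larger amounts of compound), compound 1 gives 43000 nM, the only actual number among the two values reported. Compound 2 gives > 200000 nM, which is a limit of the assay and not a number, namely (the limit of > 200000 nM in this assay, at which 1 of the 2 values shown sits). So compound 1 stands as the one compound with a measured value, and a weak one at that.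

Compound 3 `O=C(O)c1ccc(CN2CCC[C@H](O[C@H](CO)c3cc(Cl)cc(Cl)c3)[C@@H]2c2ccccc2)cc1` has not been measured. It differs from compound 1 in one place: a group of 9 heavy atoms (7 carbon, 2 oxygen; one six-membered aromatic ring of carbon only) in place of a group of 12 heavy atoms (8 carbon, 2 nitrogen, 2 oxygen; one five-membered aromatic ring with 2 hetero atoms, one six-membered aromatic ring of carbon only), on a saturated chain carbon bound to an amine nitrogen in a ring. Among the measured compounds shown here, no step between two measured compounds is available to say how large such a change usually is, so the expectation rests on compound 1 and on the fact that compound 2 returned only a limit. Compound 3 is expected to land close to compound 1 or at somewhat larger amounts, with the step of a 1.9-fold higher number from compound 1 to compound 3 (0.27 log units; within the scatter) expected to be modest and toward weaker effect. For compound 3 the estimate in this assay is 80000 nM, between 30000 nM and 200000 nM, with a real chance that only a limit is reported.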

Compound 3, half-maximal effective concentration: 77000 nM
The estimate for compound 3 lay 1.0-fold (0.02 log units) above the measured number; measured number inside the range.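

In this assay, putting 4-carboxyphenyl in place of the larger group of compound 1, on a saturated chain carbon bound to an amine nitrogen in a ring, gives a 1.8-fold higher number from compound 1 to compound 3 (0.25 log units; within the scatter). The two groups therefore cannot be told apart in this assay, and the five-membered aromatic ring with 2 hetero atoms, which leaves with this change, is not required for an effect of this size: with only a six-membered aromatic ring of carbon only in that place, the compound still gives a real number and not a limit. Nothing measured here gives a reason for this result, or shows what the two groups have in common that could account for it.

From the compounds shown here alone, whether an amide or a tetrazole in place of the carboxylic acid of 4-carboxyphenyl, or a pyridine ring in place of its carbon ring, would move the number beyond the usual scatter remains open. Compound 2 gives > 200000 nM, which is a limit of the assay and not a number, and it differs from compound 3 in more than one place, so it cannot show which of its changes matters.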